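Removing the Carboxymethyl Group from Compound 2

A few compounds are considered here, and "the series" means these few. Any claim that something is new, unique, unknown or untested is made for them only; others in the source may bear on it.

In a functional assay on NCI-H441 cells (Homo sapiens) for antiproliferative activity, with a stated time of 24 h (a higher number here means a weaker inhibitor, a lower number a stronger inhibitor), compound 2 `O=C(O)CCC(=O)N1C/C(=C\c2ccccc2F)C(=O)/C(=C/c2ccccc2F)C1` gives 69000 nM. This lies within the scatter of compound 3 `O=C(O)CCCC(=O)N1C/C(=C\c2ccccc2F)C(=O)/C(=C/c2ccccc2F)C1` at 60000 nM, and also of compound 1 `O=C1C(Cc2ccccc2F)CNCC1Cc1ccccc1F` at 130000 nM. Compound 4 `CC(=O)N1C/C(=C\c2ccccc2F)C(=O)/C(=C/c2ccccc2F)C1` differs from compound 2 by hydrogen in place of carboxymethyl on a saturated chain carbon bound to a carbonyl carbon, which shortens the chain so that 2-carboxyethyl becomes methyl. Going by the values given here, the one measured step on this chain, a 1.2-fold lower number from compound 2 to compound 3 (0.06 log units; within the scatter), keeps the carboxy group and therefore does not test its loss. Any expectation is thus tentative, and the estimate is a 2.3-fold lower number from compound 2 to compound 4 (0.36 log units; beyond the scatter), a modest step toward a stronger inhibitor. For compound 4 the expected value is 30000 nM, with an estimated range of 8000 nM to 90000 nM.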

Compound 4, half-maximal inhibitory concentration: 54000 nM
Beside the measured number, compound 4's estimate is 1.8-fold (0.26 log units) below it; measured number inside the range.
By their numbers in this assay, from the lowest: compounds 4, 3, 2 and 1 (each within the scatter of the next, the first and the last beyond it).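

In this assay the change gives a 1.3-fold lower number from compound 2 to compound 4 (0.11 log units; within the scatter) and a 1.1-fold lower number from compound 3 to compound 4 (0.05 log units; within the scatter) at this saturated chain carbon bound to a carbonyl carbon. Where the earlier step kept the carboxy group, these steps remove it, and neither carboxymethyl nor 2-carboxyethyl gives a difference beyond the scatter from hydrogen here. No measurement shown offers an explanation for this result. As far as these compounds go, whether an amine in place of the carboxylic acid would also stay within the scatter remains open, as does the outcome for a longer chain that carries no carboxy group.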